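A few compounds are considered here, and "the series" means these few. Any claim that something is new, unique, unknown or untested is made for them only; others in the source may bear on it.

Compound 1 `CC1(C)[C@H]2CC[C@]1(C)N(Cc1cn(-c3cccc(F)c3)nn1)C(=O)C2`: 90 nM
Compound 2 `CC1(C)[C@H]2CC[C@]1(C)N(Cc1cn(-c3ccccc3Br)nn1)C(=O)C2`: 60 nM

In a functional assay on LoVo cells (Homo sapiens) for inhibition, read by MTT assay, with a stated time of 24 h (a higher number here means a weaker inhibitor, a lower number a stronger inhibitor), compound 2 gives 60 nM and compound 1 gives 90 nM. Within the data shown here, these two numbers lie within the scatter of each other, so compound 2 cannot be separated from its only measured neighbour.

Compound 3 `CC1(C)[C@H]2CC[C@]1(C)N(Cc1cn(-c3cccc(Cl)c3)nn1)C(=O)C2` has 3-chlorophenyl in place of 2-bromophenyl on an aromatic nitrogen. Among the measured compounds shown here, one measured step bears on this change: a 1.5-fold lower number from compound 1 to compound 2 (0.18 log units; within the scatter), which exchanges the group on that same nitrogen and stays within the scatter. For the measured compounds named here, with only this small step as a guide, no change beyond the scatter is expected in this assay, and no direction can be firmly expected. The expected change is a 1.3-fold higher number from compound 2 to compound 3 (0.10 log units; within the scatter). For compound 3 the estimated value is 75 nM, with an expected range of 28 nM to 200 nM.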

Compound 3, half-maximal inhibitory concentration: 70 nM
Beside the measured number, compound 3's estimate is 1.1-fold (0.03 log units) above it; low and high end bracket the measured number.
By their numbers in this assay, from the lowest: compounds 2, 3 and 1 (each within the scatter of the next).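

In this assay, the exchange of 2-bromophenyl for 3-chlorophenyl on the aromatic nitrogen gives a 1.2-fold higher number from compound 2 to compound 3 (0.07 log units; within the scatter), so a change of both halogen and its place on the phenyl ring does not separate the two compounds. The new compound also provides a comparison in which only the halogen changes, chloro for fluoro on an aromatic carbon, and this gives a 1.3-fold lower number from compound 1 to compound 3 (0.11 log units; within the scatter). All three halogen-bearing phenyl groups therefore read alike in this assay, and no measured evidence is available to explain this.

The compounds shown carry only halogen-bearing phenyl groups on this nitrogen, which leaves open how the number would respond to an amine or a carboxylic acid on the phenyl ring, or to a longer alkyl chain in its place. The separate contributions of halogen and ring place also remain unresolved, as both change at once in the step from 2-bromophenyl to 3-chlorophenyl.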